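Swapping a Saturated Ring for a Fluorophenyl on the Amide

The compounds below may be only part of what the source reports. "The series", "measured", "known", "first", "only" and "open" are said of these compounds alone.

Compound 1 `CCCCC(=O)Nc1ccc(N2CCN(c3ccc(OC[C@@H]4CO[C@@](Cn5cncn5)(c5ccc(Cl)cc5Cl)O4)cc3)CC2)cc1`: 14100 nM
Compound 2 `CCC(=O)Nc1ccc(N2CCN(c3ccc(OC[C@@H]4CO[C@@](Cn5cncn5)(c5ccc(Cl)cc5Cl)O4)cc3)CC2)cc1`: 5460 nM
Compound 3 `O=C(CC1CCOCC1)Nc1ccc(N2CCN(c3ccc(OC[C@@H]4CO[C@@](Cn5cncn5)(c5ccc(Cl)cc5Cl)O4)cc3)CC2)cc1`: 21100 nM

All three were tested in a functional assay on HepG2 cells (Homo sapiens) for inhibition, read by MTT assay, with a stated time of 48 h; on this read-out lower numbers stand for stronger inhibition and higher numbers for weaker inhibition. Compound 3 has the highest number of the three: its step from compound 1, a 1.5-fold higher number from compound 1 to compound 3 (0.18 log units; within the scatter), stays within the scatter, while a 3.9-fold higher number from compound 2 to compound 3 (0.59 log units; beyond the scatter) lies beyond it.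

Compound 4, `O=C(Nc1ccc(N2CCN(c3ccc(OC[C@@H]4CO[C@@](Cn5cncn5)(c5ccc(Cl)cc5Cl)O4)cc3)CC2)cc1)c1cccc(F)c1`, differs from compound 3 in one place: 3-fluorophenyl in place of (oxan-4-yl)methyl on a carbonyl carbon. The two measured steps that reach compound 3 both exchange a group on a saturated chain carbon bound to a carbonyl carbon, and the oxan-4-yl group gave the highest number there. Among the compounds with values here, compound 4 instead places an aromatic ring directly on the carbonyl carbon, a kind of change for which no measured step exists, so the direction is uncertain. Since the move away from oxan-4-yl was flat or lower in both cases, a step no larger than those is expected, leaning lower.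

For compound 4 the expected value in this assay is 11000 nM, with a range from 4000 nM to 30000 nM, a step of a 1.9-fold lower number from compound 3 to compound 4 (0.28 log units; within the scatter).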

Compound 4, half-maximal inhibitory concentration: 10800 nM
Beside the measured number, compound 4's estimate is 1.0-fold (0.01 log units) above it; the measured number falls inside the stated range.
By their numbers in this assay, from the lowest: compounds 2, 4, 1 and 3 (each within the scatter of the next, the first and the last beyond it).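

In this assay, 3-fluorophenyl placed directly on the carbonyl carbon gives a number that cannot be separated from any of the three earlier amides (a 2.0-fold lower number from compound 3 to compound 4 (0.29 log units; within the scatter)) (a 2.0-fold higher number from compound 2 to compound 4 (0.30 log units; within the scatter)) (a 1.3-fold lower number from compound 1 to compound 4 (0.12 log units; within the scatter)). This position therefore takes an aromatic ring of carbon only, with no hydrogen-bond acceptor, in place of the (oxan-4-yl)methyl group and its one acceptor, with the change staying within the scatter. Nothing available explains this outcome.

The compounds shown leave open what a plain phenyl group or a pyridyl ring on the carbonyl carbon would give, and so whether the fluorine matters here. They also leave open what a benzyl group on that carbon would give, which would combine a saturated chain carbon with an aromatic ring.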